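Ethoxycarbonyl for hydroxymethyl on the pyrazole-type core

A few compounds are considered here, and "the series" means these few. Any claim that something is new, unique, unknown or untested is made for them only; others in the source may bear on it.

The series shares a core carrying a phenoxyphenyl group and a benzyl-linked crotonamide, and it is read in a functional assay on Z-138 cells (Homo sapiens) for inhibition, read by luminescence and CellTiter-Glo, with a stated time of 72 h; a lower number here means a stronger inhibitor, a higher number a weaker inhibitor. Compound 3 `C/C=C/C(=O)Nc1ccc(Cn2nc(-c3ccc(Oc4ccccc4)cc3)cc2CO)cc1` gives 54500 nM. Compound 1 `C/C=C/C(=O)Nc1ccc(Cn2nc(-c3ccc(Oc4ccccc4)cc3)cc2C(=O)OCC)cc1` gives only a limit in this assay, > 60000 nM, and that limit is the limit of > 60000 nM in this assay, at which 1 of the 3 values shown sits. Between them stands one change, (ethoxycarbonyl in place of hydroxymethyl on an aromatic carbon), which gave an at least 1.1-fold higher number from compound 3 to compound 1 (0.04 log units; that floor lies within the scatter); because the value of compound 1 is the limit of > 60000 nM in this assay, at which 1 of the 3 values shown sits, the true size of that step is not known beyond its floor.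

Compound 2 `C/C=C/C(=O)Nc1cccc(Cn2nc(-c3ccc(Oc4ccccc4)cc3)cc2CO)c1` gives 5700 nM and holds the lowest of the two numbers in this assay, the nearest being compound 3 at a step beyond the scatter. The difference between the cores of compound 2 and compound 3 is not broken down here.

Compound 4 `C/C=C/C(=O)Nc1cccc(Cn2nc(-c3ccc(Oc4ccccc4)cc3)cc2C(=O)OCC)c1` has not been measured in this assay. It differs from compound 2 by ethoxycarbonyl in place of hydroxymethyl on an aromatic carbon, the same change that separates compound 3 from compound 1. On that one earlier step, which ran toward a weaker number but whose size is hidden by the limit, compound 4 is expected to sit higher than compound 2 by a 3.5-fold higher number from compound 2 to compound 4 (0.55 log units; beyond the scatter). The estimate for compound 4 in this assay is 20000 nM, expected to fall between 5000 nM and 80000 nM, with a real chance that only a limit is reported.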

Compound 4, half-maximal inhibitory concentration: 8900 nM
Beside the measured number, compound 4's estimate is 2.2-fold (0.35 log units) above it, and the stated range covers the measured number.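

In this assay, ethoxycarbonyl in place of hydroxymethyl on the core of compound 2 gives a 1.6-fold higher number from compound 2 to compound 4 (0.19 log units; within the scatter), and the same change on the core of compound 3 can be read only through its floor: the same change on two cores in this assay, an at least 1.1-fold higher number (0.04 log units; that floor lies within the scatter) from compound 3 to compound 1 and a 1.6-fold higher number (0.19 log units; within the scatter) from compound 2 to compound 4; the limit leaves it open whether they differ Compound 1 carries only a limit, and the step on its core therefore has no known size: the limit of > 60000 nM in this assay, at which 1 of the 4 values shown sits. With ethoxycarbonyl held fixed, 3-(((prop-1-en-1-yl)carbonyl)amino)phenyl in place of 4-(((prop-1-en-1-yl)carbonyl)amino)phenyl gives an at least 6.7-fold lower number from compound 1 to compound 4 (0.82 log units; beyond the scatter), so the two ethoxycarbonyl compounds do not read alike, but one measured step and one floor neither establish nor exclude that the hydroxymethyl to ethoxycarbonyl change carries over from one core to the other.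

The compounds shown leave open how other groups at this place would read on either core, such as a carboxylic acid, a primary amide or an ester with a longer chain. Also open, going by these compounds, is how compound 2 and compound 4 would read with a saturated propanamide in place of the crotonamide.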